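The source may hold more compounds than are shown below. What is called first, only, known or untested is meant among the compounds shown, and "the series" means these compounds.

The compounds measured so far, with their results in an assay on CHO cells with prostaglandin D2 receptor 2 (Homo sapiens) as the target; on this read-out lower numbers stand for stronger inhibition and higher numbers for weaker inhibition:

Compound 1, `Cc1ccc(S(=O)(=O)n2c(C)c(CC(=O)O)c3cc(F)ccc32)cc1`, gives 2180 nM.
Compound 2, `Cc1c(CC(=O)O)c2cc(F)ccc2n1S(=O)(=O)c1cccc(F)c1`, gives 639 nM.
Compound 3, `COc1ccc(S(=O)(=O)n2c(C)c(CC(=O)O)c3cc(F)ccc32)cc1`, gives 318 nM.

All three share one core and differ only in the group attached to the sulfonyl sulfur. Compound 3 has the lowest number of the three in this assay, though its gap to compound 2 lies within the scatter, so the two cannot be ranked against each other; only compound 1 stands clearly apart, as seen in the step of a 6.9-fold lower number from compound 1 to compound 3 (0.84 log units; beyond the scatter).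

Compound 4, `Cc1nc(S(=O)(=O)n2c(C)c(CC(=O)O)c3cc(F)ccc32)cn1C`, has not yet been measured. It differs from compound 3 in one place: 1,2-dimethyl-1H-imidazol-4-yl in place of 4-methoxyphenyl on a sulfonyl sulfur.

Every measured step bears on this change, since each one swaps the group on the sulfonyl sulfur. The step of a 3.4-fold lower number from compound 1 to compound 2 (0.53 log units; beyond the scatter) and the step of a 6.9-fold lower number from compound 1 to compound 3 (0.84 log units; beyond the scatter) were both modest, and the step of a 2.0-fold lower number from compound 2 to compound 3 (0.30 log units; within the scatter) stayed within the scatter. The group on the sulfonyl sulfur therefore moves the number, but not greatly. The change to compound 4 is larger than any of these swaps, replacing a six-membered carbon ring with a five-membered ring holding two hetero atoms, which makes the outcome less certain.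

For compound 4 the expected outcome in this assay is a step of a 2.5-fold higher number from compound 3 to compound 4 (0.40 log units; beyond the scatter), a somewhat higher number. The estimate for compound 4 is 800 nM, with a range from 200 nM to 4000 nM.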

Compound 4, half-maximal inhibitory concentration: > 10000 nM
Compound 4: no number, only a limit; the forecaster's own chance of this, stated with the estimate: 5%; at least 12-fold (1.09 log units) between middle value and limit.
By their numbers in this assay, from the lowest: compounds 3 and 2 (each within the scatter of the next); then compound 1. At a limit, above all of these: compound 4.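

In this assay compound 4 gives no number, only a limit of the assay: the limit of > 10000 nM in this assay, at which 1 of the 4 values shown sits.

Until now, swapping the group on the sulfonyl sulfur moved the number only modestly or within the scatter, but those swaps all kept a six-membered aromatic ring of carbon only, and 1,2-dimethyl-1H-imidazol-4-yl shows that this position does not accept every aromatic ring equally, with an at least 31-fold higher number from compound 3 to compound 4 (1.49 log units; beyond the scatter) and an at least 15-fold higher number from compound 2 to compound 4 (1.19 log units; beyond the scatter), both large. Even the compound with the highest number so far is passed, with an at least 4.5-fold higher number from compound 1 to compound 4 (0.66 log units; beyond the scatter), so this single change moves the number further than any earlier swap, and all three new steps give only a minimum size.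

Compound 4 brings in a five-membered ring, ring nitrogens and methyl groups on that ring all at once, so the compounds shown cannot say which of these goes with the higher number. From the compounds shown here alone, how a pyridinyl group, which keeps the six-membered ring but holds a ring nitrogen, or an unsubstituted imidazolyl group, which lacks the methyl groups, would read on the sulfonyl sulfur stays open.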